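Swapping a Fluorophenyl for a Methylpyrazole on a Shared Core

The source may hold more compounds than are shown below. What is called first, only, known or untested is meant among the compounds shown, and "the series" means these compounds.

Compound 1 `COc1ccc(-c2c(C)nn(-c3nc(-c4ccc(Cl)c(Cl)c4)c(SC(C)C)s3)c2C(=O)O)cc1`: 2100 nM
Compound 2 `Cc1nn(-c2nc(-c3ccc(Cl)c(Cl)c3)c(SC(C)C)s2)c(C(=O)O)c1-c1cccc(F)c1`: 900 nM

In a functional assay on BJAB cells (Homo sapiens) for antiproliferative activity, with a stated time of 4 days (a higher number here means that more compound is needed for the effect, a lower number that less compound is needed), compound 1 gives 2100 nM and compound 2 gives 900 nM. Among the measured compounds shown here, compound 2 thus stands lowest of the two numbers, the only other being compound 1. For the measured compounds named here, the single measured step, a 2.3-fold lower number from compound 1 to compound 2 (0.37 log units; beyond the scatter), came with 3-fluorophenyl in place of 4-methoxyphenyl on an aromatic carbon.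

Compound 3 `Cc1nn(-c2nc(-c3ccc(Cl)c(Cl)c3)c(SC(C)C)s2)c(C(=O)O)c1-c1cnn(C)c1` differs from compound 2 by 1-methyl-1H-pyrazol-4-yl in place of 3-fluorophenyl on an aromatic carbon. Going by the values given here, the one measured step touches the same position but trades one six-membered ring for another, so it bears only loosely on a change to a five-membered ring with two nitrogen atoms. The expectation is therefore no step beyond the scatter in this assay, with a wide range around it. Compound 3 is estimated at 1500 nM, between 500 nM and 4500 nM. This estimate means a 1.7-fold higher number from compound 2 to compound 3 (0.22 log units; within the scatter).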

Compound 3, half-maximal effective concentration: 6800 nM
Compound 3: middle estimate off by 4.5-fold (0.66 log units), on the low side; measured number outside the range, above it.
By their numbers in this assay, from the lowest: compound 2; then compound 1; then compound 3.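

In this assay, the 1-methyl-1H-pyrazol-4-yl group gives the highest number of the three groups seen at this position (with a 7.6-fold higher number from compound 2 to compound 3 (0.88 log units; beyond the scatter)) and also stands above the 4-methoxyphenyl group (with a 3.2-fold higher number from compound 1 to compound 3 (0.51 log units; beyond the scatter)). The two earlier compounds showed only how one six-membered aromatic ring of carbon compares with another; this result adds that, among these three compounds, a five-membered aromatic ring with 2 hetero atoms gives a higher number than either of them. No measurement here accounts for this rise.

The compounds shown cannot separate the part played by ring size from that of the ring nitrogens or the methyl group. On these data alone, it remains open whether a plain phenyl, a pyridine ring or a pyrazole without its methyl would fall nearer compound 2 or compound 3.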